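The source may hold more compounds than are shown below. What is called first, only, known or untested is meant among the compounds shown, and "the series" means these compounds.

Measured compounds:
- compound 1, `CCOC(=O)c1ccc2[nH]c(-c3ccc(Cl)cc3)c(Oc3ccc(Cl)cc3)c2c1`: 35000 nM
- compound 2, `CCOC(=O)C1CCN(C(=S)Sc2c(-c3ccc(Br)cc3)[nH]c3ccc(Cl)cc23)CC1`: 33000 nM

Both numbers come from a functional assay on U-373MG ATCC cells (Homo sapiens) for inhibition, read by MTT assay, with a stated time of 72 h; on this read-out lower numbers stand for stronger inhibition of growth and higher numbers for weaker inhibition of growth. In this assay compound 1 gives 35000 nM and compound 2 gives 33000 nM; the two values lie within the usual scatter of each other, so the data cannot set one apart from the other, and both stand at the weak end of growth inhibition.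

Compound 3, `COc1ccc2[nH]c(-c3ccc(Cl)cc3)c(Oc3ccc(Cl)cc3)c2c1`, has not yet been measured. It differs from compound 1 in one place: methoxy in place of ethoxycarbonyl on an aromatic carbon

Going by the values given here, no pair of measured compounds shows what such a change does here, so the expectation rests only on the weak growth inhibition of compound 1 itself. With nothing to point either way, the step from compound 1 to compound 3 is expected to stay within the scatter, at a 1.2-fold lower number from compound 1 to compound 3 (0.07 log units; within the scatter). Compound 3 is therefore estimated at 30000 nM, with a range from 10000 nM to 90000 nM.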

Compound 3, concentration for 50% growth inhibition: 50000 nM
The estimate for compound 3 lay 1.7-fold (0.22 log units) below the measured number; the range from low to high includes it.
By their numbers in this assay, from the lowest: compounds 2, 1 and 3 (each within the scatter of the next).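

In this assay, putting methoxy in place of ethoxycarbonyl on this aromatic carbon gives a 1.4-fold higher number from compound 1 to compound 3 (0.15 log units; within the scatter), so the data cannot tell the two compounds apart. Going by these compounds alone, this is the first direct test of this position, and it shows that exchanging the ethoxycarbonyl for a group with fewer heavy atoms, one fewer hydrogen-bond acceptor and no double bond leaves growth inhibition at the weak end. Nothing available explains why the exchange makes so little difference.

Still open, going by these compounds, is whether a quite different group on this carbon, such as an amine or a carboxylic acid, would give clearly stronger growth inhibition. It is also unknown whether the methoxy exchange would read the same way with other groups elsewhere on the shared core.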